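The compounds below may be only part of what the source reports. "The series", "measured", "known", "first", "only" and "open" are said of these compounds alone.

Of the compounds shown here, two built on a shared core have been tested in a functional assay on CHO-K1 cells (Cricetulus griseus) for inhibition, read by sulforhodamine B assay, with a stated time of 72 h; a lower number here means a stronger inhibitor, a higher number a weaker inhibitor. Compound 1 (`COc1cc(/C=C/C(=O)/C=C(/C=C/c2ccc(OC(C)=O)c(OC)c2)NC2CCCCC2)ccc1OC(C)=O`) gives > 25000 nM, which is a limit of the assay and not a number. Compound 2 (`C=CCNC(=C\C(=O)/C=C/c1ccc(O)c(OC)c1)/C=C/c1ccc(O)c(OC)c1`) gives > 25000 nM, also a limit, and so stands at the limit of > 25000 nM in this assay, at which 2 of the 2 values shown sit. Going by the values given here, no measured step connects the two compounds, so the data give no size for any structural change. Compound 3 (`COc1cc(/C=C/C(=O)/C=C(/C=C/c2ccc(O)c(OC)c2)NCC(C)C)ccc1O`) has not yet been measured. It differs from compound 2 in one place: isopropyl in place of vinyl on a saturated chain carbon bound to an amine nitrogen, with isopropyl in place of vinyl on a saturated chain carbon bound to an amine nitrogen, which turns allylamino into isobutylamino. In this assay, no shift beyond the usual scatter is expected, and another limit is the likeliest result. The expected change is a step that the limit leaves unreadable from compound 2 to compound 3. For compound 3 the estimated half-maximal inhibitory concentration is 30000 nM, within an expected range of 10000 nM to 60000 nM.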

Compound 3, half-maximal inhibitory concentration: > 25000 nM
Compound 3 gave a limit, no number; the forecaster's own chance of this, stated with the estimate: 70%; the middle value is on the limit's open side.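

Going by these compounds alone, compound 2 and compound 3 both give only a limit of the assay, so the change from allylamino to isobutylamino yields no step that can be read in this assay. The compounds shown leave open what structure, if any, would give a measurable value, since all remain at one limit: the limit of > 25000 nM in this assay, at which 3 of the 3 values shown sit.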